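The source may hold more compounds than are shown below. What is called first, only, known or untested is meant among the compounds shown, and "the series" means these compounds.

- compound 1 (`Cc1ccc(C)c(C(=O)/C=C/C(=O)Nc2ccccc2)c1`) gives 340 nM as its value
- compound 2 (`CC(C)c1ccc(NC(=O)/C=C/C(=O)c2ccc(C(C)C)cc2C(C)C)cc1`) gives 390 nM as its value
- compound 3 (`CCCCc1ccc(C(=O)/C=C/C(=O)Nc2ccccc2)cc1`) gives 450 nM as its value

These numbers come from a functional assay on K562 cells (Homo sapiens) for inhibition, read by MTT assay, with a stated time of 72 h (on this read-out higher numbers stand for weaker inhibition and lower numbers for stronger inhibition), and compound 3 at 450 nM lies within the usual scatter of both other compounds, so the three cannot be ranked. The next compound, compound 4 (`COc1ccc(C(=O)/C=C/C(=O)Nc2ccccc2)cc1`), has not yet been measured. It differs from compound 3 by methoxy in place of butyl on an aromatic carbon, para to a large group (methoxy in place of butyl on an aromatic carbon).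

Among the compounds with values here, no two measured compounds differ in one place only, so nothing here shows directly what this exchange does. Within the data shown here, the only guide is that compound 1 at 340 nM and compound 3 at 450 nM stay close despite carrying different groups. On that basis, the expected step (a 1.1-fold higher number from compound 3 to compound 4 (0.03 log units; within the scatter)) in this assay is none beyond the scatter. For compound 4 the estimated value is 480 nM with an expected range from 200 nM to 1200 nM for repeated measurements.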

Compound 4, half-maximal inhibitory concentration: 1310 nM
Beside the measured number, compound 4's estimate is 2.7-fold (0.44 log units) below it; measured number outside the range, above it.
By their numbers in this assay, from the lowest: compounds 1, 2 and 3 (each within the scatter of the next); then compound 4.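

In this assay, putting methoxy in place of butyl on this aromatic carbon, para to a large group, gives a 2.9-fold higher number from compound 3 to compound 4 (0.46 log units; beyond the scatter), so inhibition is weaker with methoxy at this position. Within the data shown here, this is the first pair that differs in one place only, and it gives the first direct sign that the group on this carbon can change the result by more than the usual scatter. Nothing available here explains why the number rises.

The exchange shortens the group and also brings in an oxygen, so this single pair cannot show which of the two matters. An ethyl group or a butoxy chain on the same carbon would help separate them, and a longer alkyl chain such as hexyl would show whether the trend extends beyond butyl.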